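Isobutyl for Isopropyl on Two Cores in MRC5 Cells

The compounds below may be only part of what the source reports. "The series", "measured", "known", "first", "only" and "open" are said of these compounds alone.

Compound 1 `C=CCONC(=O)CN1C(=O)S/C(=C\c2cccc(C(=O)N[C@@H](CC(C)C)C(=O)OC)c2)C1=O` and compound 2 `C=CCONC(=O)CN1C(=O)S/C(=C\c2cccc(C(=O)N[C@H](C(=O)OC)C(C)C)c2)C1=O` share one core, while compound 3 `C=CCONC(=O)Cn1cc(C(=O)N[C@@H](C)C(=O)N[C@H](C(=O)O)C(C)C)c2ccccc21` and compound 4 `C=CCONC(=O)Cn1cc(C(=O)N[C@@H](C)C(=O)N[C@@H](CC(C)C)C(=O)O)c2ccccc21` share another; the difference between the two cores is not broken down here.

In a functional assay on MRC5 cells (Homo sapiens) for inhibition, read by microscopy and resazurin assay, with a stated time of 72 h (a lower number here means a stronger inhibitor, a higher number a weaker inhibitor), compound 2 gives > 128000 nM, which is a limit of the assay and not a number. Compound 1 gives > 128000 nM, again a limit. The change from compound 2 to compound 1 is isobutyl in place of isopropyl on a saturated chain carbon bound to an amide-type nitrogen and a carbonyl carbon. The step that the two limits leave unreadable from compound 2 to compound 1 cannot be sized, as both ends are limits; what the two values show is only (the limit of > 128000 nM in this assay, at which 3 of the 3 values shown sit).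

Compound 3 gives > 128000 nM, once more a limit. From compound 3 to compound 4 the same change is made, (isobutyl in place of isopropyl on a saturated chain carbon bound to an amide-type nitrogen and a carbonyl carbon), on the same place on the chain.

For compound 4 the same outcome is expected: a limit rather than a number, so that the estimated step that the limit leaves unreadable from compound 3 to compound 4 is not expected to be readable either. This expectation rests on compound 2 and compound 1, whose values both sit at the limit of > 128000 nM in this assay, at which 3 of the 3 values shown sit, and on compound 3 sitting at the same limit with > 128000 nM. Compound 4 is therefore estimated at 200000 nM, with an expected range from 100000 nM to 500000 nM, pending the measurement.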

Compound 4, half-maximal inhibitory concentration: > 128000 nM
Compound 4 gave a limit, no number; the forecaster's own chance of this, stated with the estimate: 90%; the middle value is on the limit's open side.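

In this assay compound 4 gives > 128000 nM and this is a limit of the assay, not a number. Going by these compounds alone, compound 3 also sits at a limit, so no step from compound 3 to compound 4 can be read, and the same holds for compound 2 and compound 1: (the limit of > 128000 nM in this assay, at which 4 of the 4 values shown sit). The compounds shown leave open how strongly any of them acts here, and whether isobutyl and isopropyl differ on either core.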